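Lengthening the Chain End: An Expectation for Compound 4

The source may report more compounds than this note shows. Statements on the series, on what has been measured and on what is new or still open speak of the compounds shown alone.

Three compounds share a core and differ in the tail that ends the chain. Compound 1 `CN(C)C(=O)c1cc2cnc(Nc3ccc(S(=O)(=O)NCCCN=C=S)cc3)nc2n1C1CCCC1` gives 72.8% in a functional assay on NCI-H1299 cells (Homo sapiens) for inhibition, read by CCK-8 assay, with a stated time of 72 h, tested at 10 uM; a lower number here means a weaker effect, a higher number a stronger effect of the compound at the concentration tested. Compound 2 `CN(C)C(=O)c1cc2cnc(Nc3ccc(S(=O)(=O)NCCCCN=C=S)cc3)nc2n1C1CCCC1` gives 72.7% in this assay, and the change a group of 4 heavy atoms (2 carbon, 1 nitrogen, 1 sulfur; no ring) in place of a group of 3 heavy atoms (1 carbon, 1 nitrogen, 1 sulfur; no ring), on a saturated chain carbon, three bonds along the chain from a sulfonamide nitrogen made a step of a number 0.1 percentage points lower from compound 1 to compound 2 (within the scatter). Compound 3 `CN(C)C(=O)c1cc2cnc(Nc3ccc(C(=O)NCCCCN=C=S)cc3F)nc2n1C1CCCC1` gives 78.9% in this assay; the difference between its core and the core of compound 1 is not broken down here. Compound 4 `CN(C)C(=O)c1cc2cnc(Nc3ccc(C(=O)NCCCCCN=C=S)cc3F)nc2n1C1CCCC1` is not yet measured. It differs from compound 3 by a group of 4 heavy atoms (2 carbon, 1 nitrogen, 1 sulfur; no ring) in place of a group of 3 heavy atoms (1 carbon, 1 nitrogen, 1 sulfur; no ring), on a saturated chain carbon, four bonds along the chain from an amide-type nitrogen, the same kind of change as from compound 1 to compound 2, though here the place is four bonds along the chain from an amide-type nitrogen rather than three bonds along the chain from a sulfonamide nitrogen. Because the earlier step was a number 0.1 percentage points lower from compound 1 to compound 2 (within the scatter), the expected step is a number 0.9 percentage points lower from compound 3 to compound 4 (within the scatter). Compound 4 is therefore estimated at 78%, most likely between 68% and 88%.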

Compound 4, a percentage reported as inhibition, at one concentration (the size of the read-out at that concentration, not a potency): 86.7%
Compound 4: middle estimate off by 8.7 percentage points, on the low side; the range from low to high includes it.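

In this assay, putting the group of 4 heavy atoms in place of the group of 3 heavy atoms gave a step of a number 7.8 percentage points higher from compound 3 to compound 4 (within the scatter). The two cores give no sign that this change behaves differently from one to the other: the same change on two cores in this assay, a number 0.1 percentage points lower (within the scatter) from compound 1 to compound 2 and a number 7.8 percentage points higher (within the scatter) from compound 3 to compound 4, 7.9 percentage points apart, within the scatter of two such steps This does not prove that the change carries over unaltered, and it does not show that the longer chain end raises inhibition, since neither step can be told from scatter.

The compounds shown leave open whether a longer chain would produce a step beyond the scatter. They also leave open what an amine or a carboxylic acid at the chain end would do.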